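Working notes: cytotoxicity series, step from compound 2 to compound 4

A few compounds are considered here, and "the series" means these few. Any claim that something is new, unique, unknown or untested is made for them only; others in the source may bear on it.

Three compounds carry numbers in a functional assay on HCT-116 cells (Homo sapiens) for cytotoxicity, read by MTT assay, with a stated time of 2 days, tested at 10 uM; a lower number here means less inhibition, a higher number more inhibition at the concentration tested (going by the name of the read-out). Compound 1 `c1coc(CNc2nc(NCCCN3CCCC3)nc3ccccc23)c1` gives 67.5%. Compound 2 `CCCCCNc1nc(NCc2ccco2)c2cc(F)ccc2n1` gives 94.2%. Compound 3 `Clc1cccc(N2CCN(CCCCNc3nc(NCc4ccco4)c4ccccc4n3)CC2)c1Cl` gives 94.7%. On these numbers compound 2 stands second highest of the three; its nearest neighbour is compound 3, separated from it by an amount within the scatter, while compound 1 lies furthest, lower by an amount beyond the scatter.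

Compound 4 `COc1ccc(Nc2nc(NCc3ccco3)c3cc(F)ccc3n2)cc1` is not yet measured in this assay. It differs from compound 2 in one place: 4-methoxyphenyl in place of pentyl on a nitrogen on an aromatic ring. Among the compounds with values here, no two measured compounds differ in a single place, so nothing measured shows how such a change plays out here. With compound 2 already giving 94.2%, little room remains upward; a modest fall, or no step beyond the scatter, is expected. Compound 4 is estimated at 84%, with a range from 60% to 97%. This means an expected step of a number 10.2 percentage points lower from compound 2 to compound 4 (beyond the scatter).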

Compound 4, a percentage reported as inhibition, at one concentration (the size of the read-out at that concentration, not a potency): 74%
Compound 4: the middle estimate sits 10 percentage points above what was measured; measured number inside the range.
By their numbers in this assay, from the lowest: compounds 1 and 4 (each within the scatter of the next); then compounds 2 and 3 (each within the scatter of the next).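

Within the data shown here, this is the first single-place comparison: in this assay, (4-methoxyphenyl)amino in place of pentylamino gives a number 20.2 percentage points lower from compound 2 to compound 4 (beyond the scatter) and shows that the group on this nitrogen affects the read-out. The change does not abolish inhibition, as compound 4 still gives 74%. No measured evidence bears on the reason for this step.

As far as these compounds go, whether the step follows from the aromatic ring or from its methoxy group stays open. Plain phenyl, a morpholine-bearing chain or a longer chain such as heptyl at this position would help to define the change.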